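The source may hold more compounds than are shown below. What is called first, only, known or untested is meant among the compounds shown, and "the series" means these compounds.

Measured in a functional assay on KB 3-1 cells (Homo sapiens) for cytotoxicity, read by MTT assay, with a stated time of 68 h; a higher number here means a weaker inhibitor, a lower number a stronger inhibitor:
Compound 1, `O=C(Nc1cccc(-c2ccsc2)c1)C(Cl)Cl`: > 50000 nM, a limit of this assay.
Compound 2, `Nc1cccc(-c2cccc(NC(=O)C(Cl)Cl)c2)c1`: 26100 nM.
Compound 3, `COc1ccccc1-c1cc(NC(=O)C(Cl)Cl)cc(-c2ccccc2OC)c1`: > 30000 nM, a limit of this assay.

Compound 1 stands at the limit of > 50000 nM in this assay, at which 1 of the 3 values shown sits, and so gives no number. Compound 3 stands at the limit of > 30000 nM in this assay, at which 1 of the 3 values shown sits. Only compound 2 returns a measured figure, and a weak one. Compound 4, `O=C(Nc1cccc(-c2ccccn2)c1)C(Cl)Cl`, differs from compound 1 by pyridin-2-yl in place of thiophen-3-yl on an aromatic carbon. For the measured compounds named here, no measured pair in this set differs in one place, so no step size is known for a change of this kind. Given that compound 1 sits at a limit, no movement beyond the scatter is expected in either direction. For compound 4 in this assay the estimate is 45000 nM, with a range of 15000 nM to 120000 nM. That estimate corresponds to an expected step of an at least 1.1-fold lower number from compound 1 to compound 4 (0.04 log units; that floor lies within the scatter), most likely reported again only as a limit.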

Compound 4, half-maximal inhibitory concentration: > 50000 nM
Compound 4: a limit, no number (the forecaster's own chance of this, stated with the estimate: 65%); middle value at least 1.1-fold (0.04 log units) away from the limit.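

Compound 1 and compound 4 are both reported only as limits in this assay, and the step between them cannot be read. The compounds shown leave open whether pyridin-2-yl in place of thiophen-3-yl changes the half-maximal inhibitory concentration at all.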